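Tert-butyl for methyl on a benzyl group: expected clearance

A few compounds are considered here, and "the series" means these few. Any claim that something is new, unique, unknown or untested is made for them only; others in the source may bear on it.

This account follows a pair of spiro-linked amines that share one core. Going by the values given here, compound 1 `Cc1ccc(CN2CCC3(CC2)OCCc2sccc23)cc1` carries a methyl on its benzyl ring, and in an ADME assay on microsomes from liver (Homo sapiens) for metabolic stability, read by LC-MS, using NADPH, with a stated time of 30 min, tested at 0.5 uM (on this read-out lower numbers stand for slow clearance and higher numbers for fast clearance), compound 1 gives 22.5 mL/min/g, the only number available. Compound 2 `Cc1ccccc1CN1CCC2(CC1)OCCc1sccc12`, which carries its methyl at a different position of the same ring, is recorded in this assay as "not determined" (no result reported), so nothing can be said of how the two measured structures compare. Compound 3 `CC(C)(C)c1ccc(CN2CCC3(CC2)OCCc2sccc23)cc1` is obtained from compound 1 by the change (tert-butyl in place of methyl on an aromatic carbon), on an aromatic carbon of a six-membered aromatic ring of carbon only, para to a large group. Among the compounds with values here, no step between measured compounds is available to anchor this change. A modest upward step in clearance is expected, of a size a 1.4-fold higher number from compound 1 to compound 3 (0.15 log units; within the scatter), close to the edge of the usual scatter. For compound 3 a clearance of 32 mL/min/g is estimated, with a likely range from 16 mL/min/g to 65 mL/min/g.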

Compound 3, intrinsic clearance in a liver preparation (reported as CLH), per the amount of preparation that the assay uses: 9.9 mL/min/g
Estimate against measurement, compound 3: 3.2-fold (0.51 log units) above; the whole stated range lies above it.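

With this result, the place on the benzyl ring that holds the methyl of compound 1 gains its first measured step: in this assay, tert-butyl in place of methyl on an aromatic carbon, para to a large group, gives a 2.3-fold lower number from compound 1 to compound 3 (0.36 log units; beyond the scatter) and so goes with slower clearance, not faster. Going by these compounds alone, this single pair is the only comparison, since compound 2 has no number to set beside either compound. No measurement shown here bears on why the step runs in this direction.

As far as these compounds go, it remains open whether other groups at this place, such as trifluoromethyl, a carboxylic acid or an amine, would shift clearance the same way. From the compounds shown here alone, it is equally open whether tert-butyl would have a similar effect at the ring position that carries the methyl of compound 2.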